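Swapping the phenyl ketone for an aminothiophene

This account rests on a few compounds, and the source may have more. Where it says the series, first, only, none or still open, it means among the compounds named here.

Compound 1: `COc1ccc(-c2cc3ccccc3nc2/C=C/C(=O)c2ccccc2)cc1`; in a functional assay on MCF7 cells (Homo sapiens) for antiproliferative activity, read by XTT assay, with a stated time of 72 h (a higher number here means a weaker inhibitor, a lower number a stronger inhibitor), compound 1 gives 4040 nM
Compound 2: `COc1ccc(-c2cc3ccccc3nc2/C=C/C(=O)c2ccc([N+](=O)[O-])cc2)cc1`; compound 2 gives 4110 nM
Compound 3: `COc1ccc(-c2cc3ccccc3nc2/C=C/C(=O)c2ccsc2)cc1`; compound 3 gives 6010 nM

Compound 1 has the lowest of the three numbers, but the steps of a 1.0-fold higher number from compound 1 to compound 2 (0.01 log units; within the scatter) and a 1.5-fold higher number from compound 1 to compound 3 (0.17 log units; within the scatter) both fall within the scatter, so the three measured compounds cannot be told apart on these numbers. Compound 4 is `COc1ccc(-c2cc3ccccc3nc2/C=C/C(=O)c2sccc2N)cc1` and differs from compound 1 in one place: 3-aminothiophen-2-yl in place of phenyl on a carbonyl carbon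

Within the data shown here, two measured steps bear on this change. The closest is a 1.5-fold higher number from compound 1 to compound 3 (0.17 log units; within the scatter), where a five-membered sulfur ring also replaced the phenyl on the carbonyl carbon and the number barely moved. The step of a 1.0-fold higher number from compound 1 to compound 2 (0.01 log units; within the scatter) shows that adding a group to that ring likewise left the number where it was. On this basis no step beyond the scatter is expected for compound 4, and the expected step is a 1.4-fold higher number from compound 1 to compound 4 (0.13 log units; within the scatter). Compound 4 is therefore estimated at 5500 nM, with a range from 2200 nM to 14000 nM.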

Compound 4, half-maximal inhibitory concentration: > 10000 nM
Compound 4 gave a limit, no number (the forecaster's own chance of this, stated with the estimate: 10%); middle value at least 1.8-fold (0.25 log units) away from the limit.
By their numbers in this assay, from the lowest: compounds 1, 2 and 3 (each within the scatter of the next). At a limit, above all of these: compound 4.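

In this assay, compound 4 carries a limit and not a number: the limit of > 10000 nM in this assay, at which 1 of the 4 values shown sits. Even so, the group on this carbonyl carbon can shift the result beyond the scatter, which none of the earlier changes did: the steps are an at least 2.4-fold higher number from compound 1 to compound 4 (0.39 log units; beyond the scatter) and an at least 2.4-fold higher number from compound 2 to compound 4 (0.38 log units; beyond the scatter). The step of an at least 1.6-fold higher number from compound 3 to compound 4 (0.22 log units; that floor lies within the scatter) has a floor within the scatter, so these values do not settle whether 3-aminothiophen-2-yl differs from thiophen-3-yl.

Left open is whether the amine or the ring's point of attachment goes with this shift, as 3-aminothiophen-2-yl differs from thiophen-3-yl in both; a plain thiophen-2-yl ketone and an aminophenyl ketone would pull the two apart. Going by these compounds, how far the true value of compound 4 lies past its limit also stays open.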